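Removing the acetyl from compound 3: an estimate

The compounds below may be only part of what the source reports. "The series", "measured", "known", "first", "only" and "open" are said of these compounds alone.

Compound 3 `COc1ccc(Cc2ccc3cc(NC(=O)c4ccc(OC(C)=O)c(CC=C(C)C)c4)c(=O)oc3c2C)cc1` gives 11500 nM in a functional assay on MCF7 cells (Homo sapiens) for antiproliferative activity; on this read-out lower numbers stand for stronger inhibition and higher numbers for weaker inhibition. Among the numbers shown it stands lowest; the nearest is compound 1 `COc1cccc(Oc2ccc3cc(NC(=O)c4ccc(O)c(CC=C(C)C)c4)c(=O)oc3c2C)c1`, which in this assay gives 62800 nM, a gap that lies beyond the scatter. Compound 2 `COc1ccc(Nc2ccc3cc(NC(=O)c4ccc(O)c(CC=C(C)C)c4)c(=O)oc3c2C)cc1` shows only a limit of the assay, > 100000 nM, in this assay. Compound 4 `COc1ccc(Cc2ccc3cc(NC(=O)c4ccc(O)c(CC=C(C)C)c4)c(=O)oc3c2C)cc1` differs from compound 3 by hydrogen in place of acetyl on an oxygen on an aromatic ring.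

Among the measured compounds shown here, the one measured step, an at least 1.5-fold higher number from compound 1 to compound 2 (0.20 log units; that floor lies within the scatter), concerns a different position of the shared core and offers no direct guidance on what the acetyl contributes. Compounds 1 and 2 carry the hydroxy group and lie well above compound 3, but they also differ from compound 3 in the linker, so no clean comparison exists. For the measured compounds named here, with no step bearing on the change, the expectation for compound 4 rests on compound 3 alone, with a wide range.

Compound 4 is therefore expected to give about 15000 nM in this assay, within 5000 nM to 60000 nM, a step of a 1.3-fold higher number from compound 3 to compound 4 (0.12 log units; within the scatter) expected to lie within the scatter.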

Compound 4, half-maximal inhibitory concentration: 13300 nM
Beside the measured number, compound 4's estimate is 1.1-fold (0.05 log units) above it; the range from low to high includes it.
By their numbers in this assay, from the lowest: compounds 3 and 4 (each within the scatter of the next); then compound 1. At a limit, above all of these: compound 2.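

In this assay, the acetyl on this oxygen makes no readable difference: a 1.2-fold higher number from compound 3 to compound 4 (0.06 log units; within the scatter) shows that acetoxy and hydroxy cannot be told apart here. With the hydroxy held constant, the carbon substituent can now be compared directly, and 4-methoxybenzyl in place of 3-methoxyphenoxy gives a 4.7-fold lower number from compound 1 to compound 4 (0.67 log units; beyond the scatter), while in place of (4-methoxyphenyl)amino it gives an at least 7.5-fold lower number from compound 2 to compound 4 (0.87 log units; beyond the scatter). That second step is only a floor, since the value of compound 2 is a limit of the assay: the limit of > 100000 nM in this assay, at which 1 of the 4 values shown sits.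

The compounds shown leave open whether a methyl ether or a carbamate on this oxygen would also stay within the scatter of compound 4. They also leave open how a plain benzyl or a 3-methoxybenzyl group would compare with 4-methoxybenzyl on the aromatic carbon.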